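This account rests on a few compounds, and the source may have more. Where it says the series, first, only, none or still open, it means among the compounds named here.

Three compounds share one core and differ only in the group attached to one aromatic carbon. Compound 1 `C=C(Br)C(=O)Nc1cccc(-c2cn3nc(-c4ccc(CC)cc4)sc3n2)c1` gives 3300 nM in a functional assay on FM3A cells (Mus musculus) for inhibition, read by cell counting, with a stated time of 2 days; on this read-out lower numbers stand for stronger inhibition and higher numbers for weaker inhibition. Compound 2 `C=C(Br)C(=O)Nc1cccc(-c2cn3nc(Cc4cccc(OC)c4)sc3n2)c1` gives 1100 nM in this assay, and compound 3 `C=C(Br)C(=O)Nc1cccc(-c2cn3nc(-c4ccc(C)cc4)sc3n2)c1` gives 1200 nM. Compound 2 carries the lowest of the three numbers: the step of a 3.0-fold lower number from compound 1 to compound 2 (0.48 log units; beyond the scatter) lies beyond the scatter, whereas a 1.1-fold higher number from compound 2 to compound 3 (0.04 log units; within the scatter) lies within it, so compound 2 and compound 3 cannot be told apart. The step of a 2.8-fold lower number from compound 1 to compound 3 (0.44 log units; beyond the scatter) is also beyond the scatter.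

Compound 4 `COc1cccc(Cc2nn3cc(-c4cccc(N)c4)nc3s2)c1` departs from compound 2 by hydrogen in place of (1-bromoethenyl)carbonyl on a nitrogen on an aromatic ring. None of the three measured steps touches this part of the molecule; each of them concerns the group on the other aromatic carbon, while the ((1-bromoethenyl)carbonyl)amino group stays unchanged in compound 1, compound 2 and compound 3. Among the compounds with values here, the measurements therefore give no step from which the size of this change can be read, and the expectation rests on the change alone. The expected outcome in this assay is a step to a higher number, a 5.5-fold higher number from compound 2 to compound 4 (0.74 log units; beyond the scatter), held with a wide range. Compound 4 is estimated at 6000 nM, between 1000 nM and 40000 nM.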

Compound 4, half-maximal inhibitory concentration: 10000 nM
For compound 4 the middle estimate is 1.7-fold (0.22 log units) below the measured one, within the range that was stated.
By their numbers in this assay, from the lowest: compounds 2 and 3 (each within the scatter of the next); then compound 1; then compound 4.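

The ((1-bromoethenyl)carbonyl)amino group on the aromatic ring had stayed the same across compound 1, compound 2 and compound 3, so those compounds said nothing about this part of the molecule. Within the data shown here, compound 4 gives the first reading here: going from ((1-bromoethenyl)carbonyl)amino to amino, with the 3-methoxybenzyl group and the rest of the molecule unchanged, is a step of a 9.1-fold higher number from compound 2 to compound 4 (0.96 log units; beyond the scatter) in this assay, larger than any step seen so far among changes to the group on the other aromatic carbon, so the acylated nitrogen counts for more in this small set than that variation did, although compound 4 still registers a measurable number with only the amino group in place. No measured evidence shown here explains the size of this step.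

The change takes away the bromine, the carbon-carbon double bond and the carbonyl together, so the compounds shown cannot say which of these parts carries the step; an acetyl group or a propenoyl group without the bromine on the same nitrogen would begin to separate them. It also stays open whether the step would be of similar size with 4-methylphenyl or 4-ethylphenyl in place of 3-methoxybenzyl, as the amino group is shown only with 3-methoxybenzyl.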